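Shortening the amine chain of compound 2 further

The source may report more compounds than this note shows. Statements on the series, on what has been measured and on what is new or still open speak of the compounds shown alone.

Compound 2 `COc1cc(C(=O)/C=C/c2ccc(OCCCNCCCCNCCCN)cc2)cc(OC)c1OC` gives 32700 nM in a functional assay on PC-3 cells (Homo sapiens) for antiproliferative activity, read by MTT assay, with a stated time of 48 h (a higher number here means a weaker inhibitor, a lower number a stronger inhibitor), the highest of the two numbers shown, while compound 1 `COc1cc(C(=O)/C=C/c2ccc(OCCCNCCCNCCCCNCCCN)cc2)cc(OC)c1OC` gives 14000 nM. Compound 3 `COc1cc(C(=O)/C=C/c2ccc(OCCCNCCCN)cc2)cc(OC)c1OC` carries amino in place of ((3-aminopropyl)amino)methyl on a saturated chain carbon, three bonds along the chain from an amine nitrogen. Among the measured compounds shown here, the only measured step that bears on this change is a 2.3-fold higher number from compound 1 to compound 2 (0.37 log units; beyond the scatter), which likewise shortened the chain and weakened inhibition. Compound 3 is therefore expected to move further in the same direction, by roughly a 2.1-fold higher number from compound 2 to compound 3 (0.33 log units; beyond the scatter), though a single step is thin ground. The estimate for compound 3 is 70000 nM, within a range from 25000 nM to 200000 nM.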

Compound 3, half-maximal inhibitory concentration: 20400 nM
Compound 3: the middle estimate sits 3.4-fold (0.54 log units) above what was measured; measured number below the stated range.
By their numbers in this assay, from the lowest: compounds 1, 3 and 2 (each within the scatter of the next, the first and the last beyond it).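

In this assay the exchange of ((3-aminopropyl)amino)methyl for amino gives a 1.6-fold lower number from compound 2 to compound 3 (0.20 log units; within the scatter) and does not continue the weakening seen on the earlier shortening. Hydrogen in place of 4-((3-aminopropyl)amino)butyl on an amine nitrogen gives a 1.5-fold higher number from compound 1 to compound 3 (0.16 log units; within the scatter) and so leaves the shortest chain close to the longest, with no steady trend in chain length across compound 1, compound 2 and compound 3. Nothing available here explains this result. Still open, going by these compounds, is whether a hydroxyl or a carboxylic acid in place of the end amine would shift the number, and what a plain alkyl chain would give.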